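The source may report more compounds than this note shows. Statements on the series, on what has been measured and on what is new or still open speak of the compounds shown alone.

Measured so far:
compound 1 `Cc1ccc(NC(=S)OCCNC(=O)C(C)(C)Oc2ccc(Cl)cc2)cc1`: 0.0167 h
compound 2 `NC(=S)c1ccc(OC(=O)c2cccnc2)cc1`: 0.035 h

In an ADME assay for pharmacokinetics, in phosphate buffer, tested at 60 uM (a higher number here means that the compound lasts longer, a lower number that the compound disappears faster), compound 1 gives 0.0167 h, the lower of the two numbers shown; compound 2 gives 0.035 h, a gap beyond the usual scatter. Compound 3 `CC(C)(Oc1ccc(Cl)cc1)C(=O)NCCOC(=S)Nc1ccc(F)cc1` has not yet been measured in this assay. It differs from compound 1 only by fluoro in place of methyl on an aromatic carbon. Going by the values given here, no measured pair carries this change, so the step expected here is small, a 1.2-fold higher number from compound 1 to compound 3 (0.08 log units; within the scatter), with no clear direction and probably within the scatter. For compound 3 the half-life in this assay is estimated at 0.02 h, with a range from 0.008 h to 0.05 h.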

Compound 3, half-life: 0.02 h
Compound 3: middle estimate and measured number agree at the digits printed; measured number inside the range.
By their numbers in this assay, from the lowest: compounds 1, 3 and 2 (each within the scatter of the next, the first and the last beyond it).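

At this position, on an aromatic carbon para to a large group, the series now has its first step between compounds that differ in one place: in this assay, fluoro in place of methyl gives a 1.2-fold higher number from compound 1 to compound 3 (0.08 log units; within the scatter). This exchange of one heavy atom for another therefore leaves the half-life unresolved from that of the methyl parent. Nothing available bears on what sets the half-life in this pair. Open, as far as these compounds go, is whether an amine, a carboxylic acid or a methoxy group at this position would move the half-life beyond the usual scatter. Also open, from the compounds shown here alone, is whether a change elsewhere on the shared core, such as a longer chain, would do so.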